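Methoxy for hydroxy on the hydrazone aryl ring

A few compounds are considered here, and "the series" means these few. Any claim that something is new, unique, unknown or untested is made for them only; others in the source may bear on it.

Compound 1 `CSc1nn(-c2ccccc2)c2ncnc(N/N=C/c3cccc(O)c3)c12` and compound 2 `COc1cccc(/C=N/Nc2ncnc3c2c(SC)nn3-c2ccccc2)c1` share one core; compound 3 `COc1ccc(-n2nc(SC)c3c(N/N=C/c4ccc(O)cc4)ncnc32)cc1` carries another, and the difference between the two cores is not broken down here. In a functional assay on MCF7 cells (Homo sapiens) for inhibition, read by sulforhodamine B assay, with a stated time of 48 h (a higher number here means a weaker inhibitor, a lower number a stronger inhibitor), compound 1 gives 10.7 nM, compound 2 gives 11.1 nM and compound 3 gives 34.4 nM. The change from compound 1 to compound 2 is methyl in place of hydrogen on an oxygen on an aromatic ring, and it made a 1.0-fold higher number from compound 1 to compound 2 (0.02 log units; within the scatter). Compound 3 stands apart from both, its number being the highest of the three.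

Compound 4 `COc1ccc(/C=N/Nc2ncnc3c2c(SC)nn3-c2ccc(OC)cc2)cc1` is not yet measured in this assay. It arises from compound 3 by methyl in place of hydrogen on an oxygen on an aromatic ring, the same change as before, which read one bond further out is 4-hydroxyphenyl to 4-methoxyphenyl rather than 3-hydroxyphenyl to 3-methoxyphenyl. Because a 1.0-fold higher number from compound 1 to compound 2 (0.02 log units; within the scatter) stayed within the scatter, the step from compound 3 to compound 4 is expected to be small as well, a 1.0-fold higher number from compound 3 to compound 4 (0.01 log units; within the scatter). Compound 4 is therefore estimated at 35 nM, with a likely range from 15 nM to 80 nM.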

Compound 4, half-maximal inhibitory concentration: 35 nM
Estimate against measurement, compound 4: no gap at the digits printed; the range from low to high includes it.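

In this assay, methyl in place of hydrogen on the oxygen again leaves the number where it was, with a 1.0-fold higher number from compound 3 to compound 4 (0.01 log units; within the scatter). Set beside the earlier step, the change reads the same on both cores: the same change on two cores in this assay, a 1.0-fold higher number (0.02 log units; within the scatter) from compound 1 to compound 2 and a 1.0-fold higher number (0.01 log units; within the scatter) from compound 3 to compound 4, 1.0-fold (0.01 log units) apart, within the scatter of two such steps This shows that hydroxy to methoxy carried over on these two pairs in this one cell assay, but not that it would carry to other cores, and the two pairs differ in more than the core, one being 3-hydroxyphenyl to 3-methoxyphenyl and the other 4-hydroxyphenyl to 4-methoxyphenyl, so the effects of core and of place cannot be separated.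

Still open, on these data alone, is whether a group larger than methyl on that oxygen, such as ethyl or a longer chain, or an amine or a carboxylic acid in place of the hydroxy, would leave the number equally unmoved. Also open is what the difference between the two cores does on its own, as no pair shown isolates it.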